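Swapping Chloro for Trifluoromethyl in Compound 1

This account rests on a few compounds, and the source may have more. Where it says the series, first, only, none or still open, it means among the compounds named here.

Of the compounds shown here, three have so far been measured in an ADME assay on HepG2 cells (Homo sapiens) for cytotoxicity, read by MTT assay, with a stated time of 48 h; a higher number here means that more compound is tolerated, a lower number that less compound is tolerated. Compound 1 `CC(=O)OC[C@H]1O[C@H](OC[C@@H](Cn2cc(CN(c3nc(-c4ccc(Cl)cc4)no3)C3CCCCC3)nn2)OC(C)=O)C=C[C@@H]1OC(C)=O` gives 46.9 ug/mL. Compound 2 `C#CCN(c1nc(-c2cccc([N+](=O)[O-])c2)no1)C1CCCCC1` gives 45.5 ug/mL in this assay, and compound 3 `C#CCN(c1nc(-c2ccc(C)cc2)no1)C1CCCCC1` gives 91.9 ug/mL. Compound 1 stands second highest of the three numbers; its nearest neighbour is compound 2, which lies within the usual scatter of this assay, and the furthest from it is compound 3, which also lies within that scatter. No two of these measured compounds differ in only one place, so no single structural step can be read out of them.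

Compound 4 `CC(=O)OC[C@H]1O[C@H](OC[C@@H](Cn2cc(CN(c3nc(-c4ccc(C(F)(F)F)cc4)no3)C3CCCCC3)nn2)OC(C)=O)C=C[C@@H]1OC(C)=O` has not yet been measured. It differs from compound 1 in one place: trifluoromethyl in place of chloro on an aromatic carbon. For the measured compounds named here, none of the measured compounds carries this change, so nothing measured here bears directly on it. Since the three measured numbers all sit within the scatter of one another, there is no basis for expecting a step beyond the scatter in this assay. Compound 4 is therefore expected to give 45 ug/mL, with a range from 22 ug/mL to 95 ug/mL. The step of a 1.0-fold lower number from compound 1 to compound 4 (0.02 log units; within the scatter) is expected to be none beyond the scatter.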

Compound 4, half-maximal cytotoxic concentration: 81.4 ug/mL
Beside the measured number, compound 4's estimate is 1.8-fold (0.26 log units) below it; the measured number falls inside the stated range.
By their numbers in this assay, from the lowest: compounds 2, 1, 4 and 3 (each within the scatter of the next, the first and the last beyond it).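

For the compounds shown here, the pair of compound 1 and compound 4 gives the first step that can be read at a single place: in this assay, trifluoromethyl in place of chloro on an aromatic carbon, para to a large group, gives a 1.7-fold higher number from compound 1 to compound 4 (0.24 log units; within the scatter). Going by these compounds alone, at this position, then, replacing a single chlorine with a group of 4 heavy atoms does not separate the two compounds beyond the usual scatter, a statement that the earlier compounds, which differ in more than one place, could not support. Nothing available explains the size of this step or connects it to any property of the two groups.

What the compounds shown leave open is whether a different kind of group at this same place, such as an amine, a carboxylic acid or a longer alkyl chain, would give a step beyond the scatter. They also leave open whether the change from 4-chlorophenyl to 4-(trifluoromethyl)phenyl would read the same way on the smaller core of compound 3.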